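A few compounds are considered here, and "the series" means these few. Any claim that something is new, unique, unknown or untested is made for them only; others in the source may bear on it.

In an assay on isolated protein for binding affinity to 5-hydroxytryptamine receptor 1E (Homo sapiens) (on this read-out lower numbers stand for stronger inhibition and higher numbers for weaker inhibition), compound 2 `COc1ccccc1-c1cc(C2CCNC2)ccc1Cl` gives 770 nM, and compound 3 `COc1ccccc1-c1cc(C2CCN(C)C2)ccc1Cl` gives 4100 nM, the higher of the two numbers. The step of a 5.3-fold higher number from compound 2 to compound 3 (0.73 log units; beyond the scatter) lies beyond the scatter. Compound 1 `CCCN(CCC)Cc1ccc(Cl)c(-c2ccccc2OC)c1` reaches only a limit of the assay, > 10000 nM, in this assay. That limit is the limit of > 10000 nM in this assay, at which 1 of the 3 values shown sits. Compound 4 `CNCc1ccc(Cl)c(-c2ccccc2OC)c1` has not yet been measured. The change from compound 3 is (methylamino)methyl in place of 1-methylpyrrolidin-3-yl on an aromatic carbon, giving an open chain as in compound 1 but with a hydrogen on the nitrogen as in compound 2. For the measured compounds named here, no measured step matches this change; the only step, a 5.3-fold higher number from compound 2 to compound 3 (0.73 log units; beyond the scatter), concerns the methyl on the nitrogen. The expected step of a 1.4-fold lower number from compound 3 to compound 4 (0.14 log units; within the scatter) is therefore modest and uncertain. Compound 4 is estimated at 3000 nM in this assay, between 700 nM and 15000 nM.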

Compound 4, inhibition constant: 2400 nM
Compound 4: middle estimate off by 1.3-fold (0.10 log units), on the high side; low and high end bracket the measured number.
By their numbers in this assay, from the lowest: compound 2; then compounds 4 and 3 (each within the scatter of the next). At a limit, above all of these: compound 1.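

Replacing 1-methylpyrrolidin-3-yl with the open (methylamino)methyl chain gives a 1.7-fold lower number from compound 3 to compound 4 (0.23 log units; within the scatter), so on this aromatic carbon the ring can go without a clear change, while the unmethylated ring of compound 2 stays apart, with a 3.1-fold higher number from compound 2 to compound 4 (0.49 log units; beyond the scatter). On the open chain, methylamino in place of dipropylamino gives an at least 4.1-fold lower number from compound 1 to compound 4 (0.61 log units; beyond the scatter). Compound 1 stands at a limit: the limit of > 10000 nM in this assay, at which 1 of the 4 values shown sits.

Still open, going by these compounds, is how a primary aminomethyl or an ethylamino chain would read here. So is whether a piperidine ring on this carbon would match pyrrolidin-3-yl.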